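A few compounds are considered here, and "the series" means these few. Any claim that something is new, unique, unknown or untested is made for them only; others in the source may bear on it.

Working notes on the series. Three compounds carry numbers in a functional assay, with a stated time of 240 min, tested at 100 uM; on this read-out lower numbers stand for a weaker effect and higher numbers for a stronger effect at the one concentration tested. Compound 1 `COc1ccc2nc(-c3cccc(O)c3)c(=O)n(CC(=O)O)c2c1` gives 8.5%. Compound 2 `O=C(O)Cn1c(=O)c(/C=C/c2ccc(O)c(O)c2)nc2cc(O)ccc21` gives 90.4%. Compound 3 `COc1ccc2nc(CCc3ccc(O)cc3)c(=O)n(CC(=O)O)c2c1` gives 20.7%, the second highest of the three, with compound 1 nearest and lower beyond the scatter, and compound 2 far higher, also beyond the scatter.

The next compound, compound 4 `COc1ccc2nc(CCc3ccc(O)c(OC)c3)c(=O)n(CC(=O)O)c2c1`, differs from compound 3 in one place: methoxy in place of hydrogen on an aromatic carbon. Among the measured compounds shown here, no measured pair in this set shows the same change, so no step can be drawn from the numbers; the step from a 4-hydroxyphenyl to a 4-hydroxy-3-methoxyphenyl is expected to be small, in either direction, none beyond the scatter. The expected step is a number 3.3 percentage points higher from compound 3 to compound 4 (within the scatter). Compound 4 is therefore expected to give 24%, within 10% to 42%.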

Compound 4, a percentage reported as activity, at one concentration (the size of the read-out at that concentration, not a potency): 28.3%
Beside the measured number, compound 4's estimate is 4.3 percentage points below it; low and high end bracket the measured number.
By their numbers in this assay, from the lowest: compound 1; then compounds 3 and 4 (each within the scatter of the next); then compound 2.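

With methoxy in place of hydrogen on an aromatic carbon, ortho to a hydroxy group, this assay gives a number 7.6 percentage points higher from compound 3 to compound 4 (within the scatter) and so shows no change that can be told from the scatter. Among the compounds shown here, this is the first single-place comparison, and it shows that this ring position accepts a methoxy while the read-out stays within the scatter. No measurement here bears on the reason for the size of this step.

Going by these compounds, whether an amine, a chlorine or a longer ethoxy at this position would also stay within the scatter remains open. Also open, on these data alone, is whether a methoxy gives a comparable step with a different link to the shared core.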